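The compounds below may be only part of what the source reports. "The series", "measured", "known", "first", "only" and "open" are said of these compounds alone.

Measured compounds and values:

- compound 1 `Cc1nnsc1CO/N=C/c1c(C)nn(C)c1Oc1cccc(C(F)(F)F)c1` — in a functional assay on SGC-7901 cells (Homo sapiens) for inhibition, read by MTT assay, with a stated time of 48 h (a lower number here means a stronger inhibitor, a higher number a weaker inhibitor), compound 1 gives 12400 nM
- compound 2 `Cc1ccc(Oc2c(/C=N/OCc3snnc3C)c(C)nn2C)cc1` — compound 2 gives 12800 nM
- compound 3 `CCCc1nnsc1CO/N=C/c1c(C)nn(C)c1Oc1ccc(Cl)cc1` — compound 3 gives 18600 nM

Compound 3 carries the highest of the three numbers, but its gap to compound 2 and its gap to compound 1 both fall within the scatter, so nothing separates the three compounds on these numbers; all three sit in the same weak range.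

Compound 4 `CCCc1nnsc1CO/N=C/c1c(C)nn(C)c1Cl` has not been measured. Relative to compound 3 the change is chloro in place of 4-chlorophenoxy on an aromatic carbon. Going by the values given here, no step between measured compounds of this kind exists in the data, so the size and direction of the step can only be guessed. The three measured compounds all keep the aryl ether at that position, and they span no real range, so there is nothing in the numbers that points to this position as a driver of potency in either direction. The expectation for the step of a 1.3-fold higher number from compound 3 to compound 4 (0.13 log units; within the scatter) is a modest move towards a higher number, not much beyond the scatter, with a real chance the assay reports only a limit.

Compound 4 is estimated at 25000 nM, with a range from 8000 nM to 80000 nM.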

Compound 4, half-maximal inhibitory concentration: > 50000 nM
Compound 4: only a limit was reported; the forecaster's own chance of this, stated with the estimate: 30%; middle value at least 2.0-fold (0.30 log units) from the limit.
By their numbers in this assay, from the lowest: compounds 1, 2 and 3 (each within the scatter of the next). At a limit, above all of these: compound 4.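

In this assay, compound 4 gives > 50000 nM, which is a limit of the assay and not a number. Exchanging 4-chlorophenoxy for chloro on this aromatic carbon of the shared core gives an at least 2.6-fold higher number from compound 3 to compound 4 (0.42 log units; beyond the scatter), so this position can affect the read-out, something the three aryl ether compounds could not show while their values stayed within the scatter of one another. The step is a lower bound and its true size remains unknown, so the result sets a direction but gives no measure of how much the 4-chlorophenoxy group contributes: the limit of > 50000 nM in this assay, at which 1 of the 4 values shown sits.

The change removes the ether oxygen, the six-membered aromatic ring and its chlorine together, leaving open which of these parts accounts for the step, and no cause can be assigned from these values. A phenylamino group or a benzyloxy group on the same carbon, or a small group such as methoxy or a simple amine, would help separate the role of the linking atom from that of the ring.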